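Ethoxy to methoxy: the next compound in this series

The source may report more compounds than this note shows. Statements on the series, on what has been measured and on what is new or still open speak of the compounds shown alone.

Compound 1 `Cc1ccc2nc(C(=O)Nc3c(F)cc(-c4cccc(F)c4)cc3F)c(C)c(O)c2c1` and compound 2 `CCc1ccc2nc(C(=O)Nc3c(F)cc(-c4cccc(F)c4)cc3F)c(C)c(O)c2c1` share one core, while compound 3 `CCOc1ccc2nc(C(=O)Nc3c(F)cc(-c4cccc(F)c4)cc3F)c(C)c(C(=O)O)c2c1` and compound 4 `COc1ccc2nc(C(=O)Nc3c(F)cc(-c4cccc(F)c4)cc3F)c(C)c(C(=O)O)c2c1` share another; the difference between the two cores is not broken down here. In a functional assay on A-375 cells (Homo sapiens) for antiproliferative activity, read by MTT assay, with a stated time of 24 h, tested at 11.11 ug/mL (a lower number here means a weaker effect, a higher number a stronger effect of the compound at the concentration tested), compound 1 gives 17.9%, compound 2 gives 26.4% and compound 3 gives 48.3%, the highest of the three and beyond the scatter from both others. The measured change between compound 2 and compound 1 is hydrogen in place of methyl on a saturated chain carbon bound to an aromatic carbon. From compound 3 to compound 4 the same kind of change is made, (hydrogen in place of methyl on a saturated chain carbon bound to an oxygen on an aromatic ring), though the place is not identical: a saturated chain carbon bound to an oxygen on an aromatic ring rather than one bound to an aromatic carbon. Because a number 8.5 percentage points lower from compound 2 to compound 1 (within the scatter) was small, a step of similar size is expected here, so that for compound 4 the step is estimated at a number 6.3 percentage points lower from compound 3 to compound 4 (within the scatter). Compound 4 is therefore expected to give about 42%, plausibly between 25% and 58%.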

Compound 4, a percentage reported as inhibition, at one concentration (the size of the read-out at that concentration, not a potency): 35.2%
Compound 4: middle estimate off by 6.8 percentage points, on the high side, within the range that was stated.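

In this assay the change gives a number 13.1 percentage points lower from compound 3 to compound 4 (beyond the scatter) on the core of compound 3, and it cannot be told apart from the step on the core of compound 1: the same change on two cores in this assay, a number 8.5 percentage points lower (within the scatter) from compound 2 to compound 1 and a number 13.1 percentage points lower (beyond the scatter) from compound 3 to compound 4, 4.6 percentage points apart, within the scatter of two such steps

So far, the change carries across these two cores with no detectable difference in size, although one step stays within the scatter and the other goes beyond it. Going by these compounds alone, this rests on only two pairs, with the change at two different places, and does not show that the step would hold on any further core.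

From the compounds shown here alone, how a longer chain such as propoxy would read in place of the ethoxy remains open. So does the effect of an amine at that place.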